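The source may hold more compounds than are shown below. What is called first, only, known or untested is meant among the compounds shown, and "the series" means these compounds.

Measured in an assay on CHO-K1 cells for displacement of a labelled ligand from 5-hydroxytryptamine receptor 7 (Homo sapiens), read by scintillation counting; a lower number here means a stronger inhibitor, a higher number a weaker inhibitor:
compound 1 `COc1ccccc1N1CCN(CCCCC(=O)NCc2ccccc2-c2ccc(Cl)cc2)CC1` gives 25.9 nM
compound 2 `COc1ccccc1N1CCN(CCCCC(=O)NCc2ccccc2-c2c(OC)cccc2OC)CC1` gives 32.4 nM
compound 3 `COc1ccccc1N1CCN(CCCCC(=O)NCc2ccccc2-c2ccccc2)CC1` gives 37.9 nM

Compound 3 gives the highest of the three numbers, yet its gaps to compound 1 and to compound 2 are both within the scatter, so the three compounds stand level. Compound 4 `COc1ccccc1N1CCN(CCCCC(=O)NCc2ccccc2-c2cccc(C)c2)CC1` differs from compound 3 by methyl in place of hydrogen on an aromatic carbon. Within the data shown here, the steps that bear on substitution of this six-membered aromatic ring are a 1.5-fold higher number from compound 1 to compound 3 (0.17 log units; within the scatter) and a 1.2-fold higher number from compound 2 to compound 3 (0.07 log units; within the scatter); the remaining step, a 1.3-fold higher number from compound 1 to compound 2 (0.10 log units; within the scatter), reads the same way. None leaves the scatter, so a group on this ring has not yet moved this assay. For compound 4 no step beyond the scatter is expected, a 1.2-fold lower number from compound 3 to compound 4 (0.07 log units; within the scatter). The estimate for compound 4 is 32 nM, with a range of 13 nM to 80 nM.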

Compound 4, inhibition constant: 47.6 nM
For compound 4 the middle estimate is 1.5-fold (0.17 log units) below the measured one, within the range that was stated.
By their numbers in this assay, from the lowest: compounds 1, 2, 3 and 4 (each within the scatter of the next).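

Methyl on an aromatic carbon, meta to a large group, gives in this assay a step of a 1.3-fold higher number from compound 3 to compound 4 (0.10 log units; within the scatter) and so adds a new place on the ring without leaving the scatter. Against the two other substituted rings, a 1.5-fold higher number from compound 2 to compound 4 (0.17 log units; within the scatter) and a 1.8-fold higher number from compound 1 to compound 4 (0.26 log units; within the scatter) also stay within the scatter, so 3-methylphenyl stands level with them. Nothing available gives a reason for this flat picture.

From the compounds shown here alone, whether an amine, a carboxylic acid or a longer chain at this place would move the number beyond the scatter stays open.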